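Amide chain length on the compound 1 scaffold

A few compounds are considered here, and "the series" means these few. Any claim that something is new, unique, unknown or untested is made for them only; others in the source may bear on it.

Measured in an assay on brain with Translocator protein (Rattus norvegicus) as the target (on this read-out lower numbers stand for stronger inhibition and higher numbers for weaker inhibition), so far:
- compound 1 `CCN(Cc1ccccc1)Cc1nc2ccccc2c(-c2ccccc2)c1C(=O)N(CC)CC`: 373 nM
- compound 2 `CCOC(=O)c1c(N(CC)Cc2ccccc2)nc2ccccc2c1-c1ccccc1`: 540 nM
- compound 3 `CCN(CC)C(=O)c1cc(-c2ccccc2)c2ccccc2n1`: 27 nM

Compound 1 holds the second highest of the three numbers. Among the compounds with values here, its nearest neighbour on this read-out is compound 2, whose value lies within the scatter of the one for compound 1, so the two cannot be told apart here. The furthest is compound 3, which gives a markedly lower number than compound 1, and that gap lies beyond the scatter. Compound 3 is also the only one of the three without a substituted aminomethyl or amino group on the shared core, though with three compounds no pattern should be read into that.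

The next compound, compound 4 `CCCN(CCC)C(=O)c1c(CN(CC)Cc2ccccc2)nc2ccccc2c1-c1ccccc1`, keeps the core and the substituted aminomethyl group of compound 1 and differs only in the amide: dipropylamino in place of diethylamino on a carbonyl carbon. Within the data shown here, no comparable pair of measured compounds shows what this kind of exchange does here, so the expectation rests on compound 1 alone. The step from compound 1 to compound 4 is expected to be a 1.1-fold lower number from compound 1 to compound 4 (0.03 log units; within the scatter), that is, nothing beyond the scatter. Compound 4 is therefore estimated at 350 nM, in the range 120 nM to 1000 nM.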

Compound 4, half-maximal inhibitory concentration: 456 nM
The estimate for compound 4 lay 1.3-fold (0.11 log units) below the measured number, within the range that was stated.
By their numbers in this assay, from the lowest: compound 3; then compounds 1, 4 and 2 (each within the scatter of the next).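

In this assay, the amide now has its first matched exchange: dipropylamino in place of diethylamino on a carbonyl carbon gives a step that stays within the scatter (a 1.2-fold higher number from compound 1 to compound 4 (0.09 log units; within the scatter)). Going from the 5 heavy atoms of diethylamino to the 7 of dipropylamino therefore produces no change that can be resolved on this read-out, so compound 4 cannot be told apart from compound 1. This describes one pair on one scaffold, and nothing available speaks to the reason for the result.

Still open, from the compounds shown here alone, is whether the number stays equally flat with a longer chain such as dibutylamino, a shorter one such as dimethylamino, or a ring amine such as pyrrolidine on the same carbonyl carbon. Also open, going by these compounds, is whether a secondary amide carrying a single propyl chain behaves like these tertiary amides, and whether dipropylamino in place of diethylamino gives a similar step on compound 3, which has no substituted aminomethyl group.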